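The source may report more compounds than this note shows. Statements on the series, on what has been measured and on what is new or still open speak of the compounds shown alone.

Working notes on the series. In a functional assay on the whole organism for activation, with Mus musculus as the target (a lower number here means that less compound is needed, a higher number that more compound is needed for the effect), compound 1 `Cc1nccn1-c1ccc(COc2cc(F)cc(C3(C(N)=O)CCOCC3)c2)cc1` gives 4.9 mg/kg and compound 2 `CCOC1(c2cc(F)cc(OCc3ccc(-n4ccnc4C)cc3)c2)CCOCC1` gives 5 mg/kg, which is a 1.0-fold higher number from compound 1 to compound 2 (0.01 log units; within the scatter). Compound 3 `Cc1nccn1-c1ccc(COc2cc(F)cc(C3(C(=O)N(C)C)CCOCC3)c2)cc1` has only a limit, > 20 mg/kg. Compound 4 `CNC(=O)C1(c2cc(F)cc(OCc3ccc(-n4ccnc4C)cc3)c2)CCOCC1` differs from it by hydrogen in place of methyl on an amide-type nitrogen. The closest measured change is dimethylamino in place of amino, an at least 4.0-fold higher number from compound 1 to compound 3 (0.61 log units; beyond the scatter). The step from the ethoxy compound is similar, an at least 4.0-fold higher number from compound 2 to compound 3 (0.60 log units; beyond the scatter). Methylamino lies partway from the amino of compound 1 to the dimethylamino of compound 3, so a modest fall in this assay is expected, with the size uncertain. The estimated step is an at least 2.5-fold lower number from compound 3 to compound 4 (0.39 log units; beyond the scatter). For compound 4 the estimated value is 8 mg/kg, with a range of 3.5 mg/kg to 20 mg/kg.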

Compound 4, dose for half-maximal effect: 13 mg/kg
Estimate against measurement, compound 4: 1.6-fold (0.21 log units) below; low and high end bracket the measured number.
By their numbers in this assay, from the lowest: compounds 1 and 2 (each within the scatter of the next); then compound 4. At a limit, above all of these: compound 3.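

In this assay, one methyl in place of hydrogen on the amide-type nitrogen is already enough for a modest step, a 2.7-fold higher number from compound 1 to compound 4 (0.42 log units; beyond the scatter), and methylcarbamoyl in place of ethoxy on the saturated ring carbon gives a similar one, a 2.6-fold higher number from compound 2 to compound 4 (0.41 log units; beyond the scatter). Hydrogen in place of the remaining second methyl then gives an at least 1.5-fold lower number from compound 3 to compound 4 (0.18 log units; that floor lies within the scatter). That step is only a floor, because compound 3 stands at a limit: the limit of > 20 mg/kg in this assay, at which 1 of the 4 values shown sits.

From the compounds shown here alone, how a carboxylic acid or a hydroxyl on the saturated ring carbon would compare remains open. Going by these compounds, the true size of the step from dimethylamino to methylamino also remains open.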